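An isopropyl group on the ring amine of compound 3

A few compounds are considered here, and "the series" means these few. Any claim that something is new, unique, unknown or untested is made for them only; others in the source may bear on it.

In a physicochemical assay for solubility, read by HPLC, using the shake flask method, in phosphate buffer, measured as kinetic solubility, with a stated time of 20 h, at pH 6.5 (on this read-out higher numbers stand for higher solubility and lower numbers for lower solubility), compound 1 (`C[C@@H]1CN(C(=O)c2ccnc(Nc3nc4cnc(-c5ccc(F)c(C(F)(F)F)c5)cc4[nH]3)c2)C[C@H](C)N1C`) gives 180000 nM and compound 2 (`C[C@@H]1CN(C(=O)c2ccnc(Nc3nc4cnc(-c5ccc(F)c(C(F)(F)F)c5)cc4[nH]3)c2)C[C@H](C)N1CC1CC1`) gives 200000 nM while compound 3 (`O=C(c1ccnc(Nc2nc3cnc(-c4ccc(F)c(C(F)(F)F)c4)cc3[nH]2)c1)N1CC2CC1CN2`) gives 115000 nM as its result. Compound 3 therefore stands within the usual scatter of both other compounds, so these three readings cannot be told apart.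

Compound 4 (`CC(C)N1CC2CC1CN2C(=O)c1ccnc(Nc2nc3cnc(-c4ccc(F)c(C(F)(F)F)c4)cc3[nH]2)c1`) is compound 3 with a single change (isopropyl in place of hydrogen on an amine nitrogen in a ring): isopropyl in place of hydrogen on an amine nitrogen in a ring. Going by the values given here, no measured pair makes exactly this change, so the evidence is indirect. The closest step is cyclopropyl in place of hydrogen on a saturated chain carbon bound to an amine nitrogen in a ring, which gave a 1.1-fold higher number from compound 1 to compound 2 (0.05 log units; within the scatter) in that comparison. Exchanging the whole group on the carbonyl carbon gave a 1.6-fold lower number from compound 1 to compound 3 (0.19 log units; within the scatter) and a 1.7-fold lower number from compound 2 to compound 3 (0.24 log units; within the scatter) in the other two comparisons. All three steps are small and none leaves the scatter.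

In this assay the expected step is therefore modest (a 1.2-fold higher number from compound 3 to compound 4 (0.09 log units; within the scatter)) and no change beyond the scatter is expected, with little basis for a firm direction. The estimated solubility of compound 4 is 140000 nM with an expected range from 70000 nM to 260000 nM in this measurement.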

Compound 4, solubility: 155000 nM
Compound 4: middle estimate off by 1.1-fold (0.04 log units), on the low side, within the range that was stated.
By their numbers in this assay, from the lowest: compounds 3, 4, 1 and 2 (each within the scatter of the next).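

Isopropyl in place of hydrogen on the amine nitrogen gave a 1.3-fold higher number from compound 3 to compound 4 (0.13 log units; within the scatter) in this assay, and this is the first direct reading of a change at this nitrogen, which sits in a five-membered non-aromatic ring that is part of a fused or bridged system of two rings. The comparisons with the six-membered ring amides also stay within the scatter, with a 1.3-fold lower number from compound 2 to compound 4 (0.11 log units; within the scatter) and a 1.2-fold lower number from compound 1 to compound 4 (0.06 log units; within the scatter), so this read-out does not separate compound 4 from any of the other three compounds. No measurement here accounts for the size of these steps.

On this nitrogen, the compounds shown carry only hydrogen or isopropyl, so it remains open how a longer chain, a chain ending in a hydroxyl group or a carboxylic acid would read at the same place. Every step among these four compounds lies within the scatter, which leaves open whether any change at this nitrogen could produce a difference that can be told apart in this measurement.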